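This account rests on a few compounds, and the source may have more. Where it says the series, first, only, none or still open, it means among the compounds named here.

Compound 1, with the structure `Cc1ccc(-c2ccc(=O)n(-c3ccc(S(=O)(=O)NC(=O)NC4CCCCC4)cc3)n2)cc1`, was tested in a functional assay on the whole organism (blood, strain Wistar albino) for inhibition, with Rattus norvegicus as the target, read by colorimetric assay, with stated times of 15 min and 90 min, at a dose of 20 mg/kg by the oral route (a lower number here means less inhibition, a higher number more inhibition at the dose given (going by the name of the read-out)), and gave 110%. Within the data shown here, the only other compound measured in this assay is compound 2, `Cc1ccc(-c2ccc(=O)n(-c3ccc(S(=O)(=O)NC(=O)NCc4ccccc4)cc3)n2)cc1`, which carries a benzyl in place of cyclohexyl on an amide-type nitrogen and in this assay gives 119%. The step of a number 9 percentage points higher from compound 1 to compound 2 (within the scatter) lies within the scatter, so compound 1 stands alongside compound 2 rather than apart from it, and the pair shows no change that can be trusted.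

Compound 3, `Cc1cc(-c2ccc(=O)n(-c3ccc(S(=O)(=O)NC(=O)NC4CCCCC4)cc3)n2)ccc1Cl`, differs from compound 1 at another site: 4-chloro-3-methylphenyl in place of 4-methylphenyl on an aromatic carbon. Among the measured compounds shown here, no measured step touches this position; the single step in hand, from compound 1 to compound 2, concerns the amide-type nitrogen and says nothing about the aromatic carbon where the change occurs. There is therefore no basis for expecting a shift beyond the scatter in this assay, and the estimate for compound 3 simply follows compound 1, with a step of no change at the digits printed from compound 1 to compound 3 (within the scatter) that is expected to be negligible.

On this reasoning compound 3 is estimated to give 110% in this assay, within a range from 95% to 125%.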

Compound 3, a percentage reported as inhibition, in the whole organism at one dose (the size of the read-out at that dose, not a potency): 55.2%
Beside the measured number, compound 3's estimate is 54.8 percentage points above it; measured number below the stated range.
By their numbers in this assay, from the lowest: compound 3; then compounds 1 and 2 (each within the scatter of the next).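

Among these compounds, the aromatic carbon bearing this aryl group, untouched by the only earlier step, proves to matter in this assay: 4-chloro-3-methylphenyl in place of 4-methylphenyl brings a number 54.8 percentage points lower from compound 1 to compound 3 (beyond the scatter), whereas the change on the amide-type nitrogen gave only a number 9 percentage points higher from compound 1 to compound 2 (within the scatter). Thus, among the compounds shown, this is the first change to move the inhibition at the dose given by more than the scatter, and it lowers it, even though the entering group keeps the single six-membered aromatic ring of carbon only and the same counts of hydrogen-bond donors and acceptors, and differs by one chlorine among its heavy atoms. Nothing measured here accounts for the drop.

Among the compounds shown here, the single step cannot say whether the chlorine alone carries this drop or only the chlorine and the methyl together, a question that a 4-chlorophenyl or a 3-methylphenyl group on the same aromatic carbon would address. It also leaves open whether the drop would hold with benzyl in place of cyclohexyl on the amide-type nitrogen, and how a 4-methoxyphenyl group would behave at this position.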